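Methoxy in Place of Dihydroxy on a Hydrazone Aryl Group

The source may hold more compounds than are shown below. What is called first, only, known or untested is meant among the compounds shown, and "the series" means these compounds.

Measured so far:
compound 1, `O=C(N/N=C/c1cccc(O)c1)c1cccnc1Nc1cccc(C(F)(F)F)c1`, 35.8%
compound 2, `O=C(N/N=C/c1ccc(O)c(O)c1)c1cccnc1Nc1cccc(C(F)(F)F)c1`, 21.1%

Both compounds were tested in a functional assay on the whole organism (strain Wistar) for inhibition, with Rattus norvegicus as the target, read by paw edema, with a stated time of 4 h, at a dose of 10 mg/kg by the intraperitoneal route; on this read-out lower numbers stand for less inhibition and higher numbers for more inhibition at the one dose given (going by the name of the read-out). For the measured compounds named here, compound 1 gives 35.8% and compound 2 gives 21.1%, so compound 2 stands lowest of the two numbers, and the one step between them, a number 14.7 percentage points lower from compound 1 to compound 2 (beyond the scatter), is beyond the scatter.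

Compound 3, `COc1cccc(/C=N/NC(=O)c2cccnc2Nc2cccc(C(F)(F)F)c2)c1`, is not yet measured. Its change from compound 2 is 3-methoxyphenyl in place of 3,4-dihydroxyphenyl on a carbon with a double bond to nitrogen. Going by the values given here, this takes away the hydroxy group whose addition made compound 2 weaker, which is the only step that bears on the change, and it also puts a methoxy where the other hydroxy stood, for which no measured pair gives guidance. Expected, therefore, is a rise in this assay of roughly the size of a number 11.9 percentage points higher from compound 2 to compound 3 (beyond the scatter), returning toward the number of compound 1. Compound 3 is estimated at 33%, with a range from 18% to 50%.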

Compound 3, a percentage reported as inhibition, in the whole organism at one dose (the size of the read-out at that dose, not a potency): 14.9%
Beside the measured number, compound 3's estimate is 18.1 percentage points above it; measured number below the stated range.
By their numbers in this assay, from the lowest: compounds 3 and 2 (each within the scatter of the next); then compound 1.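

In this assay, methyl in place of hydrogen on the oxygen on the aromatic ring gives a number 20.9 percentage points lower from compound 1 to compound 3 (beyond the scatter) and so, like the added hydroxy, moves the number down. The exchange of 3,4-dihydroxyphenyl for 3-methoxyphenyl gives a number 6.2 percentage points lower from compound 2 to compound 3 (within the scatter), so these two quite different groups cannot be told apart at this place, and removing the second hydroxy does not by itself bring back the number of compound 1. Nothing measured here explains this outcome.

Open, going by these compounds, is how a ring carrying no oxygen group at all would read, or one carrying an amine or a carboxylic acid, and whether ethoxy would follow methoxy. With a single dose, the numbers also leave open how these compounds would compare at other doses.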